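The source may hold more compounds than are shown below. What is called first, only, known or untested is meant among the compounds shown, and "the series" means these compounds.

Measured so far:
compound 1, `Nc1scc(-c2ccc(Br)cc2)c1C(=O)c1ccccc1`: 49%
compound 2, `Nc1scc(-c2cccc(Br)c2)c1C(=O)c1ccc(Cl)cc1`: 69%

In a functional assay on CHO cells for agonist activity at adenosine receptor A1 (Homo sapiens), read by fluorescence and ERK phosphorylation, with stated times of 30 min and 1.5 h, tested at 10 uM (on this read-out lower numbers stand for a weaker effect and higher numbers for a stronger effect at the one concentration tested), compound 2 gives 69% and stands highest of the two numbers. Compound 1 gives 49% in this assay, a gap beyond the usual scatter.

Compound 3, `Nc1scc(-c2ccc(Br)cc2)c1C(=O)c1ccc(Cl)cc1`, is not yet measured. Its change from compound 2: 4-bromophenyl in place of 3-bromophenyl on an aromatic carbon. Within the data shown here, no pair of measured compounds shows this change on its own. Compound 1 also carries 4-bromophenyl, yet differs from compound 2 in a second place as well, so its lower value in this assay is only a rough pointer. A modest decrease is expected, a number 12 percentage points lower from compound 2 to compound 3 (beyond the scatter), at the edge of the scatter. Compound 3 is estimated at 57%, in the range 38% to 76%.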

Compound 3, a percentage reported as activity, at one concentration (the size of the read-out at that concentration, not a potency): 46%
Compound 3: middle estimate off by 11 percentage points, on the high side; the measured number falls inside the stated range.
By their numbers in this assay, from the lowest: compounds 3 and 1 (each within the scatter of the next); then compound 2.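

In this assay, 4-bromophenyl in place of 3-bromophenyl gives a number 23 percentage points lower from compound 2 to compound 3 (beyond the scatter), so with chloro held constant, the place of the bromine on this phenyl ring changes the read-out. Chloro in place of hydrogen gives a number 3 percentage points lower from compound 1 to compound 3 (within the scatter), so alongside 4-bromophenyl that change does not register, and the higher value of compound 2 tracks 3-bromophenyl among these compounds. Nothing available here gives a reason for either step. Going by these compounds, whether chloro in place of hydrogen has any effect alongside 3-bromophenyl remains open. So does the read-out with an amine or a methoxy group in place of the bromine.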